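The compounds below may be only part of what the source reports. "The series", "measured", "known", "first", "only" and "open" are said of these compounds alone.

The series shares one core and varies only the group on the carbonyl carbon of the side chain. Compound 1 `CCOC(=O)C1CCN(C(=O)CN2CN(c3ccccc3)C3(CCN(C(=O)c4ccc(C5CCCCC5)cc4)CC3)C2=O)CC1` carries a 4-(ethoxycarbonyl)piperidin-1-yl group there, and in an assay on HEK293 cells for displacement of a labelled ligand from NPC1-like intracellular cholesterol transporter 1 (Homo sapiens) (on this read-out higher numbers stand for weaker inhibition and lower numbers for stronger inhibition), compound 1 gives 900 nM, the lowest number of the three. Compound 2 `CC(C)(C)OC(=O)NCCCNC(=O)CN1CN(c2ccccc2)C2(CCN(C(=O)c3ccc(C4CCCCC4)cc3)CC2)C1=O` gives 6000 nM in this assay, and compound 3 `CCC1CCCN(C(=O)CN2CN(c3ccccc3)C3(CCN(C(=O)c4ccc(C5CCCCC5)cc4)CC3)C2=O)C1` gives 2600 nM, so compound 3 stands second highest of the three, with compound 2 above it and compound 1 below. The steps read: a 6.7-fold higher number from compound 1 to compound 2 (0.82 log units; beyond the scatter); a 2.9-fold higher number from compound 1 to compound 3 (0.46 log units; beyond the scatter); a 2.3-fold lower number from compound 2 to compound 3 (0.36 log units; beyond the scatter).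

Compound 4 `CC(C)(C)OC(=O)NCNC(=O)CN1CN(c2ccccc2)C2(CCN(C(=O)c3ccc(C4CCCCC4)cc3)CC2)C1=O` is the next variant: (((tert-butoxycarbonyl)amino)methyl)amino in place of 3-ethylpiperidin-1-yl on a carbonyl carbon. The entering group is a close relative of the (3-((tert-butoxycarbonyl)amino)propyl)amino group of compound 2, the methyl rather than the propyl analogue, so the step that bears most directly is a 2.3-fold lower number from compound 2 to compound 3 (0.36 log units; beyond the scatter), read in reverse; a 6.7-fold higher number from compound 1 to compound 2 (0.82 log units; beyond the scatter) points the same way, since both tert-butoxycarbonyl-amino variants give higher numbers than the piperidine amides. From the compounds shown here alone, a move back toward the number of compound 2 is therefore expected, a higher number beyond the scatter, though the exact size stays open. The estimate for compound 4 is 5000 nM, with a range of 2000 nM to 15000 nM. That estimate means a 1.9-fold higher number from compound 3 to compound 4 (0.28 log units; within the scatter), expected as a modest rise.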

Compound 4, half-maximal inhibitory concentration: 1700 nM
The estimate for compound 4 lay 2.9-fold (0.47 log units) above the measured number, and the stated range ends above it.
By their numbers in this assay, from the lowest: compounds 1, 4 and 3 (each within the scatter of the next, the first and the last beyond it); then compound 2.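

In this assay a high number does not go with the tert-butoxycarbonyl-amino side chain as such: a 1.5-fold lower number from compound 3 to compound 4 (0.18 log units; within the scatter) and a 1.9-fold higher number from compound 1 to compound 4 (0.28 log units; within the scatter) leave compound 4 level with both piperidine amides, even though a group with no ring has replaced the six-membered ring. The sharper information lies in the link inside the open chain, where a 3.5-fold lower number from compound 2 to compound 4 (0.55 log units; beyond the scatter) isolates (tert-butoxycarbonyl)amino in place of 2-((tert-butoxycarbonyl)amino)ethyl on a saturated chain carbon bound to an amide-type nitrogen, so the length of this chain matters at this position, on the evidence of this one pair. No supporting data on the compounds accompany this result, so the shift in number stays an observation without an explanation.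

From the compounds shown here alone, whether the number follows chain length steadily stays open, as an ethyl or butyl link would be needed between or beyond the two chains at hand. Also open, going by these compounds, is what happens when the tert-butoxycarbonyl group gives way to a free primary amine, or when a carboxylic acid replaces the ethyl ester of the piperidine group in compound 1.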